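Swapping an Octyl Chain for a Butylphenyl Group

The source may report more compounds than this note shows. Statements on the series, on what has been measured and on what is new or still open speak of the compounds shown alone.

Measured so far:
compound 1 `Cc1ccc(C#Cc2cn(C/C=C\CN3C(=O)c4ccccc4C3=O)c(=O)[nH]c2=O)cc1` gives the limit > 100000 nM in a functional assay on MCF7 cells (Homo sapiens) for antiproliferative activity, read by MTT assay, with a stated time of 3 days; on this read-out higher numbers stand for weaker inhibition and lower numbers for stronger inhibition
compound 2 `CCCCCCCCC#Cc1cn(C/C=C\CN2C(=O)c3ccccc3C2=O)c(=O)[nH]c1=O` gives 64000 nM
compound 3 `CCCCCCCCC#Cc1cn(C/C=C/CN2C(=O)c3ccccc3C2=O)c(=O)[nH]c1=O` gives 66000 nM

Compound 1 reaches only a limit of this assay. Compound 3 stands at the highest of the two numbers given; its nearest neighbour is compound 2, and a 1.0-fold higher number from compound 2 to compound 3 (0.01 log units; within the scatter) because of the fact that compounds 2 and 3 differ only in the configuration as drawn. Within the data shown here, the one step that bears on the new change is an at least 1.5-fold lower number from compound 1 to compound 2 (0.19 log units; that floor lies within the scatter), pointing the same way as the limit of > 100000 nM in this assay, at which 1 of the 3 values shown sits.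

Compound 4 `CCCCc1ccc(C#Cc2cn(C/C=C/CN3C(=O)c4ccccc4C3=O)c(=O)[nH]c2=O)cc1` differs from compound 3 by 4-butylphenyl in place of octyl on a triple-bonded carbon. The measured step ran from an aromatic group to octyl and gave a lower number; going back to an aromatic group is therefore expected to give a higher number, a 1.4-fold higher number from compound 3 to compound 4 (0.13 log units; within the scatter). Compound 4 is estimated at 90000 nM, between 40000 nM and 250000 nM.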

Compound 4, half-maximal inhibitory concentration: 44000 nM
The estimate for compound 4 lay 2.0-fold (0.31 log units) above the measured number; measured number inside the range.
By their numbers in this assay, from the lowest: compounds 4, 2 and 3 (each within the scatter of the next). At a limit, above all of these: compound 1.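

In this assay, the exchange on this triple-bonded carbon gives a 1.5-fold lower number from compound 3 to compound 4 (0.18 log units; within the scatter), so an open octyl chain and a 4-butylphenyl group, with its six-membered aromatic ring, cannot be told apart here. The earlier comparison of an aromatic group with octyl rested on a limit, whereas this pair has a measured number on both sides. Nothing in the data at hand explains this result. The compounds shown leave open how a chain ending in an amine or a carboxylic acid would behave on this carbon. From the compounds shown here alone, an unsubstituted phenyl group also remains open.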